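The compounds below may be only part of what the source reports. "The series", "measured", "known", "first", "only" and "open" are said of these compounds alone.

Compound 1 `CCSc1sc(-n2nc(C)c(Cc3ccccc3[N+](=O)[O-])c2C(=O)O)nc1-c1ccc(Cl)c(Cl)c1` — in a functional assay on BJAB cells (Homo sapiens) for antiproliferative activity, with a stated time of 4 days (a lower number here means that less compound is needed, a higher number that more compound is needed for the effect), compound 1 gives 59000 nM.
Compound 2 `COc1cncc(-c2c(C)nn(-c3nc(-c4ccc(Cl)c(Cl)c4)c(SC(C)C)s3)c2C(=O)O)c1` — in this assay compound 2 gives 21000 nM.
Compound 3 `COC(=O)c1c(Cc2ccccc2[N+](=O)[O-])c(C)nn1-c1nc(-c2ccc(Cl)c(Cl)c2)cs1` — in this assay compound 3 gives 377000 nM.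

Among these three, compound 2 stands lowest in this assay; compound 1 is nearest to it, with a gap beyond the usual scatter, and compound 3 lies furthest away. Compound 4 `Cc1ccc(-c2c(C)nn(-c3nc(-c4ccc(Cl)c(Cl)c4)c(SC(C)C)s3)c2C(=O)O)cc1` differs from compound 2 at a single place: 4-methylphenyl in place of 5-methoxypyridin-3-yl on an aromatic carbon. For the measured compounds named here, no step between two measured compounds mirrors this change, so there is nothing in the measured set to fix its size. Compound 4 is therefore expected to stay close to compound 2, with the estimated step of a 1.2-fold higher number from compound 2 to compound 4 (0.08 log units; within the scatter) reaching little beyond the scatter in either direction. The estimate for compound 4 in this assay is 25000 nM, with a range from 8000 nM to 80000 nM.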

Compound 4, half-maximal effective concentration: 3800 nM
Estimate against measurement, compound 4: 6.6-fold (0.82 log units) above; measured number outside the range, below it.
By their numbers in this assay, from the lowest: compound 4; then compound 2; then compound 1; then compound 3.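

For the compounds shown here, the first single change that can be read at this aromatic carbon shows that the position is sensitive in this assay: 4-methylphenyl in place of 5-methoxypyridin-3-yl gives a 5.5-fold lower number from compound 2 to compound 4 (0.74 log units; beyond the scatter) on the shared core. The all-carbon ring, without hydrogen-bond acceptors, goes with less compound being needed. Nothing available accounts for this step. The compounds shown leave open whether the ring nitrogen, the methoxy or the methyl carries the step. A plain phenyl or a 4-methoxyphenyl at this place would begin to separate them.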